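Extending the amide nitrogen substituent of compound 3

The source may hold more compounds than are shown below. What is called first, only, known or untested is meant among the compounds shown, and "the series" means these compounds.

Compound 1 `COC(=O)/C=C/c1cccc(N(Cc2ccc(/C=C/c3cccc(F)c3)cc2)C(=O)C2CCCCC2)c1` gives 86 nM in an assay on isolated protein with Bile acid receptor (Homo sapiens) as the target; on this read-out lower numbers stand for an effect already at smaller amounts and higher numbers for an effect only at larger amounts of compound.
Compound 2 `COC(=O)/C=C/c1cccc(N(Cc2ccc(-c3ccc(N(C)C)cc3)cc2)C(=O)NC(C)C)c1` gives 162 nM in this assay.
Compound 3 `COC(=O)/C=C/c1cccc(N(C)C(=O)C2CCCCC2)c1` gives > 1000 nM in this assay.

The reading for compound 3 is a limit of the assay and not a number (the limit of > 1000 nM in this assay, at which 1 of the 3 values shown sits). Of the three measured compounds, compound 3 is the one whose substituent on the amide nitrogen is only a methyl group, and it is the one that sits at the limit. Compound 4 `COC(=O)/C=C/c1cccc(N(Cc2ccccc2Br)C(=O)C2CCCCC2)c1` carries, in the words of the counted difference, (2-bromophenyl in place of hydrogen on a saturated chain carbon bound to an amide-type nitrogen). Compound 1, which carries a larger group on that same carbon, gives 86 nM, and compound 2, which also carries a larger group on that same carbon, gives 162 nM. These two values are the ground for the expectation. A step from compound 3 toward the smaller numbers is therefore expected, of the size an at least 2.5-fold lower number from compound 3 to compound 4 (0.39 log units; beyond the scatter). For compound 4 the estimated value is 400 nM, with a range from 100 nM to 2000 nM.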

Compound 4, half-maximal effective concentration: > 1000 nM
Compound 4: no number, only a limit; the forecaster's own chance of this, stated with the estimate: 30%; middle value at least 2.5-fold (0.39 log units) from the limit.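

The reading for compound 4, > 1000 nM, is a limit of the assay and not a number, as is that for compound 3, so no step from compound 3 to compound 4 can be read: the limit of > 1000 nM in this assay, at which 2 of the 4 values shown sit.

The compounds shown leave open whether 2-bromophenyl in place of hydrogen at this carbon changes the reading at all.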